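This account rests on a few compounds, and the source may have more. Where it says the series, first, only, none or still open, it means among the compounds named here.

Measured so far:
compound 1, `Cn1c(=O)c2[nH]c(SCC(=O)c3ccccc3)nc2n(C)c1=O`, gives 6700 nM in a functional assay on A549 cells (Homo sapiens) for inhibition, read by MTT assay, with a stated time of 48 h; a lower number here means a stronger inhibitor, a higher number a weaker inhibitor
compound 2, `Cn1c(=O)[nH]c2nc(SCC(=O)c3ccccc3)[nH]c2c1=O`, gives 11900 nM in this assay
compound 3, `Cn1c(=O)c2[nH]c(SC/C(=N/O)c3ccccc3)nc2n(C)c1=O`, gives 6100 nM in this assay

Compound 2 differs from compound 1 by hydrogen in place of methyl on an aromatic nitrogen. That change produced a 1.8-fold higher number from compound 1 to compound 2 (0.25 log units; within the scatter). Compound 4, `Cn1c(=O)[nH]c2nc(SC/C(=N/O)c3ccccc3)[nH]c2c1=O`, differs from compound 3 by hydrogen in place of methyl on an aromatic nitrogen, which is the same change at the same place. How the core of compound 3 differs from the core of compound 1 is not broken down here; their values in this assay lie close together, as do the values of all three measured compounds.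

Within the data shown here, because the measured step of a 1.8-fold higher number from compound 1 to compound 2 (0.25 log units; within the scatter) is the only guide to this change, compound 4 is expected to follow it. In this assay compound 4 is estimated at 11000 nM, with a likely range from 5000 nM to 25000 nM. The expected step is a 1.8-fold higher number from compound 3 to compound 4 (0.26 log units; within the scatter).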

Compound 4, half-maximal inhibitory concentration: 5600 nM
Compound 4: the middle estimate sits 2.0-fold (0.29 log units) above what was measured; measured number inside the range.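

In this assay, putting hydrogen in place of methyl on the aromatic nitrogen of the core of compound 3 gives a 1.1-fold lower number from compound 3 to compound 4 (0.04 log units; within the scatter). Set beside the earlier step on the core of compound 1, the change reads alike on both cores: the same change on two cores in this assay, a 1.8-fold higher number (0.25 log units; within the scatter) from compound 1 to compound 2 and a 1.1-fold lower number (0.04 log units; within the scatter) from compound 3 to compound 4, 1.9-fold (0.29 log units) apart, within the scatter of two such steps. This shows that the change carries between these two cores without a step beyond the scatter, but it rests on a single pair for each core, and neither step is large enough to show any effect of the methyl, nor does either say how the change would behave on a third core.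

The compounds shown leave open whether a longer chain on that aromatic nitrogen would give a step beyond the scatter. They also leave open what an amine in place of the carbonyl of compound 1 would do.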